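The source may hold more compounds than are shown below. What is called first, only, known or untested is meant among the compounds shown, and "the series" means these compounds.

Measured in a functional assay on COR-L23 cells (Homo sapiens) for antiproliferative activity, read by CellTiter-Glo, with a stated time of 72 h; on this read-out lower numbers stand for stronger inhibition and higher numbers for weaker inhibition:
- compound 1 `O=C(Nc1ccc(CN2C(=O)c3ccccc3C2=O)cc1)[C@H]1C[C@@H]1c1cccnc1`: 35 nM
- compound 2 `C[C@H](NC(=O)c1cccc(F)c1)c1ccc(NC(=O)N2CC(c3cccnc3)C2)cc1`: 10 nM

Compound 2 gives 10 nM, the lower of the two numbers. Compound 1, at 35 nM, stands higher by more than the usual scatter. The two differ in more than one place, so this gap says nothing about any single change.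

Compound 3 `C[C@H](NC(=O)[C@@H]1CCCN1C)c1ccc(NC(=O)N2CC(c3cccnc3)C2)cc1` keeps the rest of compound 2 and changes one group: 1-methylpyrrolidin-2-yl in place of 3-fluorophenyl on a carbonyl carbon. In words, 1-methylpyrrolidin-2-yl stands in place of 3-fluorophenyl on a carbonyl carbon. Among the compounds with values here, no measured pair in this set differs in one place, so the size of the step in this assay has no direct precedent and the range must stay wide. A moderate move to a higher number, meaning weaker inhibition, is expected, probably a little beyond the scatter. Within the data shown here, compound 2, at 10 nM, is the lowest number so far, which leaves more room upward than downward. The expected change is a 2.5-fold higher number from compound 2 to compound 3 (0.40 log units; beyond the scatter). For compound 3 the estimated value is 25 nM, with an expected range from 6 nM to 100 nM.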

Compound 3, half-maximal inhibitory concentration: 38 nM
Beside the measured number, compound 3's estimate is 1.5-fold (0.18 log units) below it; measured number inside the range.
By their numbers in this assay, from the lowest: compound 2; then compounds 1 and 3 (each within the scatter of the next).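

In this assay, within the data shown here, placing 1-methylpyrrolidin-2-yl in place of 3-fluorophenyl on a carbonyl carbon gives a 3.8-fold higher number from compound 2 to compound 3 (0.58 log units; beyond the scatter) as the first step that can be read at a single place. The number at this position therefore responds to the group on that carbonyl carbon, although the step is modest, and a non-aromatic five-membered ring with a hetero atom and a defined stereocentre still gives compound 3 a value of 38 nM in place of the six-membered aromatic ring of carbon only. No measurement on hand bears on the cause of this step.

The change alters ring size, aromaticity, the fluorine and the ring nitrogen together, so one step cannot assign its size to any one of these features, and it comes from a single pair on a single core. Open questions are where a plain phenyl, a pyrrolidin-2-yl without the methyl on nitrogen, a 1-methylpiperidin-2-yl or the opposite configuration of the 1-methylpyrrolidin-2-yl stereocentre would stand on this read-out.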